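This account rests on a few compounds, and the source may have more. Where it says the series, first, only, none or still open, it means among the compounds named here.

Within the data shown here, compound 1 `O=C(N/N=C/c1ccc(Cl)cc1)c1ccncc1` is the better of the two compounds measured so far. In a functional assay on the whole organism (strain C57B/6) with Mus musculus as the target, in the maximal electroshock model, with a stated time of 0.5 h (a lower number here means that less compound is needed, a higher number that more compound is needed for the effect), compound 1 gives 100 mg/kg, the lowest of the two numbers recorded. Its nearest neighbour, compound 2 `O=C(N/N=C/c1cccc(Cl)c1)c1ccncc1`, gives 300 mg/kg in this assay, a higher number that falls beyond the usual scatter of repeated measurements. Among the measured compounds shown here, no single-point step between measured compounds has been characterised, so nothing is yet known about how rearranging the shared core affects the read-out.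

Compound 3 `O=C(N/N=C/c1ccc(Cl)cc1)c1cccnc1` has not been measured. It keeps every atom of compound 1 and differs only in how they are joined: pyridin-3-yl in place of pyridin-4-yl on a carbonyl carbon. For the measured compounds named here, with no measured step of this kind to lean on, compound 3 is expected to land close to compound 1, with the step of a 1.5-fold higher number from compound 1 to compound 3 (0.18 log units; within the scatter) estimated as none beyond the scatter or a slight drift toward a higher number. The value of compound 3 in this assay is therefore estimated at 150 mg/kg, within a range from 75 mg/kg to 300 mg/kg.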

Compound 3, minimum effective dose: 100 mg/kg
Beside the measured number, compound 3's estimate is 1.5-fold (0.18 log units) above it; measured number inside the range.
By their numbers in this assay, from the lowest: compounds 1 and 3 (each within the scatter of the next); then compound 2.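

In this assay, among these compounds, the first measured step on the shared core reads no change at the digits printed from compound 1 to compound 3 (within the scatter) for pyridin-3-yl in place of pyridin-4-yl on a carbonyl carbon. Among the compounds shown here, this pair shows that, at this place, the same atoms joined in these two ways cannot be told apart in this read-out, which the earlier compounds, differing elsewhere, could not show. No measurement at hand offers a reason for this outcome.

On these data alone, whether pyridin-3-yl would give the same reading alongside the other chlorine arrangement of compound 2 stays open. As far as these compounds go, it is also open what a pyridin-2-yl or a plain phenyl group on the carbonyl carbon would give, and so whether the ring nitrogen matters at all for this read-out.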